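The source may hold more compounds than are shown below. What is called first, only, known or untested is meant among the compounds shown, and "the series" means these compounds.

Working notes on the series. In a functional assay on NCI-H460 cells (Homo sapiens) for cytotoxicity (a lower number here means a stronger inhibitor, a higher number a weaker inhibitor), compound 1 (`O=C(CCCCCCC(=O)Nc1nc2ccccc2s1)NO`) gives 5.71 ug/mL and compound 2 (`CCOc1ccc2nc(NC(=O)CCCCCCC(=O)NO)sc2c1`) gives 6.58 ug/mL. Within the data shown here, compound 2 therefore stands level with compound 1 within the scatter, and these are the only two numbers available.

Compound 3 (`COc1ccc2nc(NC(=O)CCCCCCC(=O)NO)sc2c1`) is not yet measured. Its difference from compound 2 is hydrogen in place of methyl on a saturated chain carbon bound to an oxygen on an aromatic ring, so that ethoxy becomes methoxy.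

Among the measured compounds shown here, one measured step bears on this change: a 1.2-fold higher number from compound 1 to compound 2 (0.06 log units; within the scatter), with ethoxy in place of hydrogen on an aromatic carbon. That step introduced the whole ethoxy group and stayed within the scatter, whereas the present change removes only its outer carbon. For the measured compounds named here, no measured step covers methoxy itself, so this reading is indirect.

No step beyond the scatter is therefore expected in this assay, and no direction can be assigned with confidence. The expected step is a 1.1-fold lower number from compound 2 to compound 3 (0.03 log units; within the scatter). For compound 3 the estimated value is 6.2 ug/mL, with an expected range of 3.5 ug/mL to 11 ug/mL.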

Compound 3, half-maximal inhibitory concentration: 1.25 ug/mL
Compound 3: middle estimate off by 5.0-fold (0.70 log units), on the high side, outside the stated range (below it).
By their numbers in this assay, from the lowest: compound 3; then compounds 1 and 2 (each within the scatter of the next).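

In this assay the ethoxy and hydrogen compounds gave no readable difference, which made this position look indifferent, but the change from ethoxy to methoxy gives a 5.3-fold lower number from compound 2 to compound 3 (0.72 log units; beyond the scatter) and so shows that the position does respond to the substituent. Methoxy in place of hydrogen on the aromatic carbon gives a 4.6-fold lower number from compound 1 to compound 3 (0.66 log units; beyond the scatter) as well, so compound 3 separates from both neighbours, while compound 1 and compound 2 remain level within the scatter and go against any steady trend with the length of the alkoxy chain. The response therefore depends on the single methyl at the outer end of the ethoxy group rather than on the presence of an oxygen substituent alone, and nothing available explains this sharp dependence.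

With only hydrogen, methoxy and ethoxy at this position, the compounds shown leave open whether methoxy marks a narrow optimum or whether a hydroxy group, a propoxy group or an amine on the same aromatic carbon would also give a low number. They also leave open whether the gain seen with methoxy holds in any cell line other than the one tested here.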